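1H-indazol-4-yl in place of 1H-indazol-5-yl

This account rests on a few compounds, and the source may have more. Where it says the series, first, only, none or still open, it means among the compounds named here.

In an ADME assay (liver) for metabolic stability, with Liver microsome (Rattus norvegicus) as the target, using microsomes and NADPH, with a stated time of 30 min, tested at 1 uM (a higher number here means faster removal of the compound, a lower number slower removal), compound 1 `Nc1ccc(S(=O)(=O)N2CCN(c3ncc(C(O)(C(F)(F)F)C(F)(F)F)cc3-c3ccc4sccc4c3)CC2)cn1` gives 487 mL.min-1.g-1, compound 2 `Nc1ccc(S(=O)(=O)N2CCN(c3ncc(C(O)(C(F)(F)F)C(F)(F)F)cc3-c3ccc4ocnc4c3)CC2)cn1` gives 120 mL.min-1.g-1 and compound 3 `Nc1ccc(S(=O)(=O)N2CCN(c3ncc(C(O)(C(F)(F)F)C(F)(F)F)cc3-c3ccc4[nH]ncc4c3)CC2)cn1` gives 88 mL.min-1.g-1. Compound 3 sits with compound 2 and well under compound 1: a 1.4-fold lower number from compound 2 to compound 3 (0.13 log units; within the scatter) stays within the scatter, while a 5.5-fold lower number from compound 1 to compound 3 (0.74 log units; beyond the scatter) and a 4.1-fold lower number from compound 1 to compound 2 (0.61 log units; beyond the scatter) exceed it. Compound 4 `Nc1ccc(S(=O)(=O)N2CCN(c3ncc(C(O)(C(F)(F)F)C(F)(F)F)cc3-c3cccc4[nH]ncc34)CC2)cn1` carries 1H-indazol-4-yl in place of 1H-indazol-5-yl on the same aromatic carbon: 1H-indazol-4-yl in place of 1H-indazol-5-yl on an aromatic carbon. Among the measured compounds shown here, no measured step tests such a change of attachment. The two larger steps both leave 1-benzothiophen-5-yl, which is not involved here, so a 1.4-fold lower number from compound 2 to compound 3 (0.13 log units; within the scatter) is the closer guide. The expected step is a 1.1-fold higher number from compound 3 to compound 4 (0.06 log units; within the scatter), with none beyond the scatter anticipated. The estimate for compound 4 is 100 mL.min-1.g-1, with an expected range of 40 mL.min-1.g-1 to 250 mL.min-1.g-1.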

Compound 4, intrinsic clearance in microsomes: 93 mL.min-1.g-1
Compound 4: middle estimate off by 1.1-fold (0.03 log units), on the high side; measured number inside the range.
By their numbers in this assay, from the lowest: compounds 3, 4 and 2 (each within the scatter of the next); then compound 1.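

In this assay the point of attachment on this aromatic carbon, ortho to a large group, makes no difference beyond the scatter: 1H-indazol-4-yl in place of 1H-indazol-5-yl gives (a 1.1-fold higher number from compound 3 to compound 4 (0.02 log units; within the scatter)). Compound 4 also stays within the scatter of the 1,3-benzoxazol-5-yl analogue (a 1.3-fold lower number from compound 2 to compound 4 (0.11 log units; within the scatter)), while its gap from the 1-benzothiophen-5-yl analogue exceeds it (a 5.2-fold lower number from compound 1 to compound 4 (0.72 log units; beyond the scatter)), so both indazole attachments fall with compound 2 and away from compound 1. Nothing available explains this result.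

Still open, as far as these compounds go, is whether a methyl group on the indazole ring nitrogen would keep the number at this level. A plain phenyl at the same carbon would show whether the fused five-membered ring is needed at all.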